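The compounds below may be only part of what the source reports. "The series", "measured", "known", "first", "only" and "open" are said of these compounds alone.

Compound 1 `O=c1oc2ccccc2cc1-c1cn2nc(Cc3ccc(Cl)cc3)sc2n1` and compound 2 `O=c1oc2ccccc2cc1-c1nc2sc(Cc3ccc(Cl)cc3)nn2c1Br` share one core and differ only at a single aromatic carbon, where compound 2 carries bromo in place of hydrogen. In a functional assay on HeLa cells (Homo sapiens) for cytotoxicity, with a stated time of 72 h (on this read-out lower numbers stand for stronger inhibition and higher numbers for weaker inhibition), compound 1 gives > 10000 nM, which is a limit of the assay rather than a measured number. In this assay compound 2 gives 4500 nM. The step of an at least 2.2-fold lower number from compound 1 to compound 2 (0.34 log units; beyond the scatter) is the only measured step shown, and compound 2 holds the only actual number; the other value is a limit, as noted in the limit of > 10000 nM in this assay, at which 1 of the 2 values shown sits.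

Compound 3 `O=Cc1c(-c2cc3ccccc3oc2=O)nc2sc(Cc3ccc(Cl)cc3)nn12` takes the next step from compound 2: formyl in place of bromo on an aromatic carbon. Among the measured compounds shown here, no measured step swaps bromo for formyl, so the bromo-for-hydrogen step an at least 2.2-fold lower number from compound 1 to compound 2 (0.34 log units; beyond the scatter) is the only guide, and it rests on one side on the limit (the limit of > 10000 nM in this assay, at which 1 of the 2 values shown sits). Formyl is a different kind of group from bromo, so the direction of the change cannot be read from that step. The expectation for compound 3 is therefore a number near that of compound 2, with the step of a 1.3-fold higher number from compound 2 to compound 3 (0.12 log units; within the scatter) likely inside the usual scatter. Compound 3 is estimated at 6000 nM, in the range 2000 nM to 20000 nM.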

Compound 3, half-maximal inhibitory concentration: 900 nM
Beside the measured number, compound 3's estimate is 6.7-fold (0.82 log units) above it; measured number outside the range, below it.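

In this assay, the group on this aromatic carbon does more than simply fill the place, since replacing one substituent with another still moves the number, giving a 5.0-fold lower number from compound 2 to compound 3 (0.70 log units; beyond the scatter). Measured against the unsubstituted carbon, formyl gives an at least 11-fold lower number from compound 1 to compound 3 (1.04 log units; beyond the scatter), so among these three compounds the order runs from hydrogen through bromo to formyl, with formyl giving the lowest number and each printed step lying beyond the scatter. The value of compound 1 in that comparison is a limit of the assay and not a number: the limit of > 10000 nM in this assay, at which 1 of the 3 values shown sits.

The compounds shown leave open whether this gain belongs to formyl alone or extends to other groups on the same carbon, such as an amine, a carboxylic acid or a hydroxymethyl group. They also cannot separate the possible contributions of what formyl brings and bromo lacks, namely a double bond outside the aromatic rings and a hydrogen-bond acceptor, as the two arrive together in a single swap and a simple ketone or a nitrile would be needed to pull them apart.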